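Swapping a Pyrrolidine Chain for a Hydroxyethyl Amide

The source may hold more compounds than are shown below. What is called first, only, known or untested is meant among the compounds shown, and "the series" means these compounds.

Compound 2 `Cn1ncc(Cl)c1-c1cc(C(=O)N[C@@H]2CN[C@H](CCN3CCCC3)C[C@H]2c2ccc(Cl)c(Cl)c2)oc1Cl` shares a core with compound 1 `Cn1ncc(Cl)c1-c1cc(C(=O)N[C@@H]2CN[C@H](CCO)C[C@H]2c2ccc(F)c(F)c2)oc1Cl` and compound 3 `Cn1ncc(Cl)c1-c1cc(C(=O)N[C@@H]2CN[C@H](CC(O)CO)C[C@H]2c2ccc(F)c(F)c2)oc1Cl` but differs from both in two places. In a functional assay on LNCaP cells (Homo sapiens) for antiproliferative activity (a lower number here means a stronger inhibitor, a higher number a weaker inhibitor), compound 1 gives 60 nM, compound 3 gives 100 nM, and compound 2 gives 1920 nM, the highest of the three numbers by a margin that lies beyond the scatter.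

The new compound 4 `Cn1ncc(Cl)c1-c1cc(C(=O)N[C@@H]2CN[C@H](CC(=O)NCCO)C[C@H]2c2ccc(Cl)c(Cl)c2)oc1Cl` keeps the aromatic part of compound 2 and changes the chain on the saturated ring: (2-hydroxyethyl)carbamoyl in place of (pyrrolidin-1-yl)methyl on a saturated chain carbon bound to a saturated ring carbon. Among the measured compounds shown here, the only step measured on one change alone is a 1.7-fold higher number from compound 1 to compound 3 (0.22 log units; within the scatter), which adds an oxygen-bearing carbon to a chain and hardly moves this assay. For the measured compounds named here, no measured step removes a (pyrrolidin-1-yl)methyl group, so the direction here can be read only loosely from the fact that compounds 1 and 3, whose chains also carry oxygen, sit well below compound 2.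

Compound 4 is therefore expected to move toward those numbers, with a 3.8-fold lower number from compound 2 to compound 4 (0.58 log units; beyond the scatter) as the guess. The estimate for compound 4 is 500 nM, within 120 nM to 2000 nM.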

Compound 4, half-maximal inhibitory concentration: 40 nM
Beside the measured number, compound 4's estimate is 13-fold (1.10 log units) above it, outside the stated range (below it).
By their numbers in this assay, from the lowest: compounds 4, 1 and 3 (each within the scatter of the next, the first and the last beyond it); then compound 2.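

In this assay the change at this one place alone brings a 48-fold lower number from compound 2 to compound 4 (1.68 log units; beyond the scatter) and so shows that this chain on the saturated ring can strongly shift the number while the rest of compound 2 stays fixed. Among the compounds shown here, the earlier compounds could not show this: their only single-change step, a 1.7-fold higher number from compound 1 to compound 3 (0.22 log units; within the scatter), is small and lies within the scatter. Nothing available here explains why (2-hydroxyethyl)carbamoyl gives so much lower a number than (pyrrolidin-1-yl)methyl.

As far as these compounds go, it remains open whether the gain comes from losing the pyrrolidine ring, gaining the amide carbonyl, or gaining the hydroxyl, since all three change together in this step. A plain primary amide, a carboxylic acid, or a longer hydroxyalkyl amide chain at this place would help to separate these possibilities.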